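A few compounds are considered here, and "the series" means these few. Any claim that something is new, unique, unknown or untested is made for them only; others in the source may bear on it.

Measured compounds:
compound 1, `CCOc1ccccc1-c1nc2cc([N+](=O)[O-])ccc2[nH]1`: 15000 nM
compound 2, `FC(F)(F)c1ccc2[nH]c(-c3ccccc3)nc2c1`: 468000 nM

In a functional assay on aorta (Rattus norvegicus, strain Wistar) for inhibition, with a stated time of 60 min (on this read-out lower numbers stand for an effect already at smaller amounts and higher numbers for an effect only at larger amounts of compound), compound 1 gives 15000 nM, the lowest of the two numbers; compound 2 gives 468000 nM, a gap beyond the scatter. Going by the values given here, no step between measured compounds differs in a single place, so the account rests on these two values alone.

Compound 3, `CC(C)Oc1ccccc1-c1nc2cc([N+](=O)[O-])ccc2[nH]1`, differs from compound 1 by methyl in place of hydrogen on a saturated chain carbon bound to an oxygen on an aromatic ring and a saturated chain carbon. Among the compounds with values here, with no comparable step measured, the change is expected to move this assay little, if at all beyond the scatter: no change at the digits printed from compound 1 to compound 3 (within the scatter) is the estimate. Compound 3 is therefore expected to give 15000 nM, within 5000 nM to 45000 nM.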

Compound 3, half-maximal effective concentration: 14100 nM
The estimate for compound 3 lay 1.1-fold (0.03 log units) above the measured number, within the range that was stated.
By their numbers in this assay, from the lowest: compounds 3 and 1 (each within the scatter of the next); then compound 2.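

Going from ethoxy to isopropoxy in this assay gives a 1.1-fold lower number from compound 1 to compound 3 (0.03 log units; within the scatter) as the first single-place step in this set. It shows that this saturated chain carbon bound to the oxygen takes a methyl in place of hydrogen without a shift beyond the scatter. Nothing available explains this result.

From the compounds shown here alone, whether a longer chain such as butoxy, or an amine or carboxylic acid carried on the chain, would leave the number as level remains open. So does how far this position tolerates a ring such as cyclopentyl.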